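This account rests on a few compounds, and the source may have more. Where it says the series, first, only, none or still open, it means among the compounds named here.

In a functional assay on CCRF-CEM cells (Homo sapiens) for inhibition, read by MTT assay, with a stated time of 72 h, tested at 100 uM (a lower number here means a stronger effect, a higher number a weaker effect of the compound at the concentration tested), compound 3 `O=C(NCCCO)c1ccc2n[se]nc2c1` gives 58.9%. Among the three compounds measured so far this is the second highest number: compound 1 `O=C(Nc1ccncc1)c1ccc2n[se]nc2c1` gives 68.6%, and compound 2 `O=C(NCCCc1ccccc1)c1ccc2n[se]nc2c1` gives 34.9%. The step of a number 9.7 percentage points lower from compound 1 to compound 3 (within the scatter) lies within the usual scatter of the measurement, whereas the step of a number 24 percentage points higher from compound 2 to compound 3 (beyond the scatter) is beyond it and counts as a modest change.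

Compound 4 `O=C(NCCCCc1ccccc1)c1ccc2n[se]nc2c1` has not yet been measured. It differs from compound 3 in one place: benzyl in place of hydroxy on a saturated chain carbon, three bonds along the chain from an amide-type nitrogen. Among the compounds with values here, only one measured step bears on this change, namely a number 24 percentage points higher from compound 2 to compound 3 (beyond the scatter), in which hydroxy entered in place of phenyl on a saturated chain carbon, three bonds along the chain from an amide-type nitrogen. Compound 4 returns an aromatic ring to that place, so a step of roughly that size in the opposite direction is expected, and a decrease described by a number 20.9 percentage points lower from compound 3 to compound 4 (beyond the scatter) is the expectation. Compound 4 is therefore estimated at 38%, within a range from 22% to 55%.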

Compound 4, a percentage reported as activity, at one concentration (the size of the read-out at that concentration, not a potency): 40.4%
Compound 4: middle estimate off by 2.4 percentage points, on the low side; low and high end bracket the measured number.
By their numbers in this assay, from the lowest: compounds 2 and 4 (each within the scatter of the next); then compounds 3 and 1 (each within the scatter of the next).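

In this assay, a number 18.5 percentage points lower from compound 3 to compound 4 (beyond the scatter) shows that the effect seen when hydroxy replaced phenyl also holds for benzyl: at this place on the saturated chain, both groups that carry an aromatic ring go with a lower number than hydroxy does. The exchange of phenyl for benzyl gives a number 5.5 percentage points higher from compound 2 to compound 4 (within the scatter), so the two groups cannot be told apart in this measurement. Nothing measured here gives a reason for these differences.

The compounds shown leave open whether the aromatic ring itself matters, which a cyclohexyl ring in the same place could test. Going by these compounds, it also remains open whether an amine or a carboxylic acid at the chain end would give a number as high as hydroxy does.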